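The source may hold more compounds than are shown below. What is called first, only, known or untested is meant among the compounds shown, and "the series" means these compounds.

Measured compounds in this series:
compound 1 `Cc1ccc(CCOc2ccc(-c3c(C)nc(C)c([C@H](OC(C)(C)C)C(=O)O)c3N3CCC(C)(C)CC3)cc2)cc1`; in a toxicity assay on MT2 cells (Homo sapiens) for cytotoxicity, read by XTT assay, with a stated time of 4 days (on this read-out higher numbers stand for lower toxicity in this test and lower numbers for higher toxicity in this test), compound 1 gives >= 33500 nM, which is a limit of the assay, not a number.
compound 2 `Cc1nc(C)c([C@H](OC(C)(C)C)C(=O)O)c(N2CCC(C)(C)CC2)c1-c1ccc(OCCc2ccc(Cl)cc2)cc1`; in this assay compound 2 gives >= 33500 nM, likewise a limit.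
compound 3 `Cc1cc(CCOc2ccc(-c3c(C)nc(C)c([C@H](OC(C)(C)C)C(=O)O)c3N3CCC(C)(C)CC3)cc2)ccc1F`; in this assay compound 3 gives >= 33500 nM, again a limit.

Compound 2 therefore stands at the limit of >= 33500 nM in this assay, at which 3 of the 3 values shown sit, and nothing separates it from the other two. The steps that touch compound 2, a step that the two limits leave unreadable from compound 1 to compound 2 and a step that the two limits leave unreadable from compound 2 to compound 3, are both of unreadable size, both ends sitting at the limit.

Compound 4 `Cc1nc(C)c([C@H](OC(C)(C)C)C(=O)O)c(N2CCC(C)(C)CC2)c1-c1ccc(OCCc2cccnc2)cc1` differs from compound 2 as follows: pyridin-3-yl in place of 4-chlorophenyl on a saturated chain carbon, two bonds along the chain from an oxygen on an aromatic ring. The measured steps give no readable size, so for compound 4 the expected step is a number no higher from compound 2 to compound 4 (the limit leaves the size open), none beyond the scatter, and compound 4 is expected to sit at the limit again. The estimate for compound 4 in this assay is 33500 nM, with a range from 20000 nM to 33500 nM.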

Compound 4, half-maximal cytotoxic concentration: >= 25000 nM
Compound 4: a limit, no number (the forecaster's own chance of this, stated with the estimate: 85%); the middle value lies beyond the limit too.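

In this assay compound 4 gives >= 25000 nM, which is a limit. The steps joining compound 4 to compound 1, compound 2 and compound 3 cannot be read, since both ends are limits. Whether the groups exchanged among these four compounds change this read-out at all stays open.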